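Chain extension on the shared core: compound 3 to compound 4

A few compounds are considered here, and "the series" means these few. Any claim that something is new, unique, unknown or untested is made for them only; others in the source may bear on it.

In a functional assay on MDA-MB-435 cells (Homo sapiens) for cytotoxicity, read by MTT assay, with a stated time of 72 h (on this read-out higher numbers stand for weaker inhibition and lower numbers for stronger inhibition), compound 1 (`Nc1cccc(Nc2c(C(=O)NCc3ccc(F)cc3)nc(Br)c3cccnc23)c1`) gives 8000 nM, compound 2 (`Nc1ccc(Nc2c(C(=O)NCc3ccc(F)cc3)nc(Br)c3cccnc23)cc1`) gives 7000 nM and compound 3 (`NCCNc1c(C(=O)NCc2ccc(F)cc2)nc(Br)c2cccnc12`) gives 12000 nM. Compound 3 therefore stands within the scatter of both neighbours. Compound 4 (`NCCCCCCNc1c(C(=O)NCc2ccc(F)cc2)nc(Br)c2cccnc12`) replaces its 2-aminoethyl with 6-aminohexyl: 4-aminobutyl in place of amino on a saturated chain carbon, two bonds along the chain from a nitrogen on an aromatic ring. The nearest evidence is the swaps on the same nitrogen, a 1.5-fold higher number from compound 1 to compound 3 (0.18 log units; within the scatter) and a 1.7-fold higher number from compound 2 to compound 3 (0.23 log units; within the scatter), along with a 1.1-fold lower number from compound 1 to compound 2 (0.06 log units; within the scatter). All three stay within the scatter, although none of them tests chain length alone. No step beyond the scatter is therefore expected in this assay. The expected change is a 1.5-fold lower number from compound 3 to compound 4 (0.18 log units; within the scatter). Compound 4 is estimated at 8000 nM, with an expected range of 3000 nM to 18000 nM.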

Compound 4, half-maximal inhibitory concentration: 6000 nM
Compound 4: the middle estimate sits 1.3-fold (0.12 log units) above what was measured, and the stated range covers the measured number.
By their numbers in this assay, from the lowest: compounds 4, 2, 1 and 3 (each within the scatter of the next).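

In this assay, chain length alone is now tested at this nitrogen: a 2.0-fold lower number from compound 3 to compound 4 (0.30 log units; within the scatter), so 6-aminohexyl and 2-aminoethyl cannot be told apart on this read-out. The flexible chain also cannot be told apart from either aminophenyl group, with a 1.2-fold lower number from compound 2 to compound 4 (0.07 log units; within the scatter) and a 1.3-fold lower number from compound 1 to compound 4 (0.12 log units; within the scatter). No supporting evidence bears on these results. Open, going by these compounds, is whether a longer chain, or a chain ending in a carboxylic acid instead of an amine, would give a step beyond the scatter. The shared core, including its bromine and 4-fluorobenzyl amide, also stays unprobed in these compounds.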